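This account rests on a few compounds, and the source may have more. Where it says the series, first, only, none or still open, it means among the compounds named here.

Measured compounds:
Compound 1 `CCOC(=O)C1=Cc2ccccc2OC1(OCc1cn(-c2ccc(C)cc2)nn1)C(F)(F)F` gives 26700 nM in a functional assay on MCF7 cells (Homo sapiens) for inhibition, read by MTT assay, with a stated time of 24 h; on this read-out higher numbers stand for weaker inhibition and lower numbers for stronger inhibition.
Compound 2 `O=C(O)C1=Cc2ccccc2OC1(OCc1cc(-c2ccc([N+](=O)[O-])cc2)no1)C(F)(F)F` gives only a limit, > 150000 nM, in this assay.
Compound 3 `CCOC(=O)C1=Cc2ccccc2OC1(OCc1cc(-c2ccc([N+](=O)[O-])cc2)no1)C(F)(F)F` gives only a limit, > 150000 nM, in this assay.

Among the measured compounds shown here, compound 1 holds the only numerical value among the three; the other two values are limits, as the limit of > 150000 nM in this assay, at which 2 of the 3 values shown sit, records. For the measured compounds named here, the single step that can be compared, a step that the two limits leave unreadable from compound 2 to compound 3, runs between two limits and cannot be read. Going by the values given here, no measured step touches the aryl group on the five-membered ring that carries the change to compound 4.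

Compound 4 `CCOC(=O)C1=Cc2ccccc2OC1(OCc1cn(-c2cccc(C(F)(F)F)c2)nn1)C(F)(F)F` differs from compound 1 by 3-(trifluoromethyl)phenyl in place of 4-methylphenyl on an aromatic nitrogen. Among the compounds with values here, nothing among the measured compounds speaks to the size or direction of this change in this assay, so no step beyond the scatter is expected, and the estimate rests on compound 1 alone. The expected step from compound 1 to compound 4 is a 1.0-fold higher number from compound 1 to compound 4 (0.00 log units; within the scatter). Compound 4 is therefore estimated at 27000 nM in this assay, within a range from 8000 nM to 90000 nM.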

Compound 4, half-maximal inhibitory concentration: > 150000 nM
Compound 4: only a limit was reported; the forecaster's own chance of this, stated with the estimate: 25%; middle value at least 5.5-fold (0.74 log units) away from the limit.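

With 3-(trifluoromethyl)phenyl in place of 4-methylphenyl on the aromatic nitrogen, this assay records an at least 5.6-fold higher number from compound 1 to compound 4 (0.74 log units; beyond the scatter). This is the only readable step among the compounds shown, and it shows that the aryl group at this position is not indifferent to the read-out, which the earlier compounds could not show. The value of compound 4 is a limit and not a number, so the step has a lower bound only, and compound 1 remains the only compound with a numerical value: the limit of > 150000 nM in this assay, at which 3 of the 4 values shown sit.

The compounds shown do not separate the trifluoromethyl group from its position on the aryl ring, or from the removal of the methyl group. On these data alone, what a plain phenyl, or an aryl ring carrying an amine or a carboxylic acid, would give on that nitrogen stays open.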